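The source may report more compounds than this note shows. Statements on the series, on what has been measured and on what is new or still open speak of the compounds shown alone.

Compound 1 `O=C(Nc1ccccc1Br)N[C@@H]1CCN(c2cccc(F)c2)C1` gives 7.8 in a functional assay for antagonist activity at transient receptor potential cation channel subfamily V member 1 (Rattus norvegicus), read by FLIPR; a higher number here means a more potent compound, by a factor of ten per unit of this negative logarithm, a lower number a less potent compound. Compound 2 `O=C(Nc1ccccc1Br)N[C@@H]1CCN(c2ccc(Cl)cn2)C1` gives 7.3 in this assay. Compound 3 `O=C(NCCN1CCc2c(F)cccc21)Nc1ccccc1Br` gives 7.4 in this assay.

Compound 2 carries the lowest of the three numbers. Compound 3 lies within the usual scatter of it, so the two cannot be told apart, while compound 1 stands higher by an amount beyond the scatter. Among the compounds with values here, the only single-point step among the measured compounds is a number 0.50 log units lower from compound 1 to compound 2 (beyond the scatter), a swap of one whole ring for another on the amine nitrogen. Compound 4 `O=C(Nc1ccccc1Br)N[C@@H]1CCN(c2ccccn2)C1` differs from compound 2 by hydrogen in place of chloro on an aromatic carbon. Within the data shown here, no measured step removes a chloro group from this ring, so these data say nothing about how much it contributes. The change is expected to cost little: a number 0.20 log units lower from compound 2 to compound 4 (within the scatter), within the scatter. Compound 4 is therefore estimated at 7.1, with a range from 6.5 to 7.7.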

Compound 4, negative logarithm of the antagonist equilibrium constant: < 6.6
Compound 4: a limit, no number; the forecaster's own chance of this, stated with the estimate: 5%; at least 0.50 log units between middle value and limit.
By their numbers in this assay, from the lowest: compounds 2 and 3 (each within the scatter of the next); then compound 1. At a limit, below all of these: compound 4.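

For compound 4, this assay returns only a limit: the limit of < 6.6 in this assay, at which 1 of the 4 values shown sits. Even so, hydrogen in place of chloro on this aromatic carbon gives a number at least 0.70 log units lower from compound 2 to compound 4 (beyond the scatter), so the chloro group counts for more here than the earlier compounds could show. The unsubstituted pyridin-2-yl ring also compares poorly with 3-fluorophenyl on the amine nitrogen, with a number at least 1.20 log units lower from compound 1 to compound 4 (beyond the scatter).

The compounds shown cover only chloro and hydrogen at this position, so how a bromo, methyl or methoxy group would fare stays open. Going by these compounds, the true size of both steps also stays open.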